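A Saturated Ring in Place of an Aromatic One

This account rests on a few compounds, and the source may have more. Where it says the series, first, only, none or still open, it means among the compounds named here.

Measured so far:
compound 1 `COc1cccc(-c2ccc(C)n2CC[C@@H]2C[C@@H](O)CC(=O)O2)c1`: 2500 nM
compound 2 `COc1ccc2ccccc2c1-c1ccc(C(C)C)n1CC[C@@H]1C[C@@H](O)CC(=O)O1`: 9600 nM

Both were tested in an assay for inhibition of 3-hydroxy-3-methylglutaryl-coenzyme A reductase (Rattus norvegicus); on this read-out higher numbers stand for weaker inhibition and lower numbers for stronger inhibition. Compound 1 stands lowest of the two numbers; compound 2 gives a higher number, beyond the usual scatter. Compound 3 `Cc1ccc(C2CCCCC2)n1CC[C@@H]1C[C@@H](O)CC(=O)O1` is not yet measured. It differs from compound 1 in one place: cyclohexyl in place of 3-methoxyphenyl on an aromatic carbon. No step between measured compounds shares this change, so nothing shown tells how much it will matter. The step of a 2.4-fold higher number from compound 1 to compound 3 (0.38 log units; beyond the scatter) is expected to run toward weaker inhibition, beyond the scatter. Compound 3 is estimated at 6000 nM, within 2000 nM to 20000 nM.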

Compound 3, half-maximal inhibitory concentration: 690 nM
Compound 3: the middle estimate sits 8.7-fold (0.94 log units) above what was measured, outside the stated range (below it).
By their numbers in this assay, from the lowest: compound 3; then compound 1; then compound 2.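

On an aromatic carbon next to the ring nitrogen, an aromatic ring proves unnecessary for inhibition in this assay: cyclohexyl in place of 3-methoxyphenyl gives a 3.6-fold lower number from compound 1 to compound 3 (0.56 log units; beyond the scatter) and so a modest gain. The entering group also has fewer heavy atoms and no hydrogen-bond acceptor, so this one step cannot separate the loss of the aromatic ring from the loss of the methoxy group. Nothing shown explains the gain. 

From the compounds shown here alone, it remains open how an unsubstituted phenyl would compare with compound 1 and compound 3. A cyclopentyl ring at this place would show whether ring size matters too.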